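The source may hold more compounds than are shown below. What is called first, only, known or untested is meant among the compounds shown, and "the series" means these compounds.

The study is concerned with how small structural changes alter the tolerance of MT2 cells, and compound 1 `Fc1cccc(F)c1Cc1cnc(Nc2ccc(CCOc3ccncc3)cc2)o1` serves as the point of departure. In an ADME assay on MT2 cells (Homo sapiens) for cytotoxicity, read by MTT assay (on this read-out higher numbers stand for lower toxicity in this test and lower numbers for higher toxicity in this test), compound 1 gives 11000 nM. This is the lowest of the two numbers reported so far: compound 2 `OCc1ccc(Nc2ncc(Cc3c(F)cccc3F)o2)cc1Cl` gives 90000 nM in this assay, a difference that lies beyond the usual scatter of the test. Compound 3 `O=c1ncccn1SCCc1ccc(Nc2ncc(Cc3c(F)cccc3F)o2)cc1` has not yet been measured. It differs from compound 1 at a single place (a group of 8 heavy atoms (4 carbon, 2 nitrogen, 1 oxygen, 1 sulfur; one six-membered aromatic ring with 2 hetero atoms) in place of a group of 7 heavy atoms (5 carbon, 1 nitrogen, 1 oxygen; one six-membered aromatic ring with 1 hetero atom), on a saturated chain carbon, two bonds along the chain from an aromatic carbon). Among the measured compounds shown here, no measured pair shows this particular exchange, so nothing in the numbers so far fixes its effect; the two measured compounds differ elsewhere. The account therefore treats the step from compound 1 to compound 3 as an open question, and expects no step beyond the scatter, a 1.3-fold higher number from compound 1 to compound 3 (0.10 log units; within the scatter). For compound 3 the expected value in this assay is 14000 nM, with a range from 4000 nM to 50000 nM.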

Compound 3, half-maximal cytotoxic concentration: > 100000 nM
Compound 3 gave a limit, no number; the forecaster's own chance of this, stated with the estimate: 15%; at least 7.1-fold (0.85 log units) between middle value and limit.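

In this assay, replacing the (pyridin-4-yl)oxy group with the entering group, which has a six-membered aromatic ring with 2 hetero atoms and a sulfur atom, gives an at least 9.0-fold higher number from compound 1 to compound 3 (0.95 log units; beyond the scatter). This shows what compounds 1 and 2 could not: a change at this one place, on a saturated chain carbon, two bonds along the chain from an aromatic carbon, moves the read-out towards lower toxicity in this test by more than the scatter. The reading for compound 3 is a limit and not a number, so the step is bounded on one side only: the limit of > 100000 nM in this assay, at which 1 of the 3 values shown sits.

Going by these compounds, it remains open which part of the entering group goes with this step: the sulfur atom, the ring with its 2 hetero atoms, or the double bond outside aromatic rings. On these data alone, it is also open whether an amine, a carboxylic acid or a longer chain at this place would give a similar reading.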